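This account rests on a few compounds, and the source may have more. Where it says the series, first, only, none or still open, it means among the compounds named here.

Compound 1 `CCCC(=O)OCCc1c(-c2ccccc2Cl)c2cc(Cl)ccc2[nH]c1=O` gives 52000 nM in an ADME assay on HepG2 2.2.15 cells (Homo sapiens) for cytotoxicity; on this read-out lower numbers stand for higher toxicity in this test and higher numbers for lower toxicity in this test. Compound 2 `O=C(/C=C/c1cccc(F)c1)OCCc1c(-c2ccccc2Cl)c2cc(Cl)ccc2[nH]c1=O` reaches only a limit of this assay, > 1600000 nM, and so sits at the limit of > 1600000 nM in this assay, at which 1 of the 2 values shown sits, without an exact number. Going by the values given here, the single measured step, an at least 30-fold higher number from compound 1 to compound 2 (1.48 log units; beyond the scatter), bears on the change to compound 3 `C/C=C/C=C/C(=O)OCCc1c(-c2ccccc2Cl)c2cc(Cl)ccc2[nH]c1=O`, which differs from compound 2 by prop-1-en-1-yl in place of 3-fluorophenyl on a double-bonded chain carbon bound to a double-bonded chain carbon. That measured step went toward higher numbers when propyl gave way to 2-(3-fluorophenyl)ethenyl; with a shorter chain returning, compound 3 is expected to move back toward lower numbers, by an at least 5.3-fold lower number from compound 2 to compound 3 (0.72 log units; beyond the scatter). Compound 3 is therefore estimated at 300000 nM, within a range from 60000 nM to 1600000 nM.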

Compound 3, half-maximal cytotoxic concentration: 440000 nM
Beside the measured number, compound 3's estimate is 1.5-fold (0.17 log units) below it; the range from low to high includes it.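

On a carbonyl carbon, penta-1,3-dien-1-yl in place of propyl gives an 8.5-fold higher number from compound 1 to compound 3 (0.93 log units; beyond the scatter) in this assay, so a chain with no ring is enough for a clear rise in the number. Prop-1-en-1-yl in place of 3-fluorophenyl nevertheless gives an at least 3.6-fold lower number from compound 2 to compound 3 (0.56 log units; beyond the scatter), so the aromatic ring still counts at this place. The size of that second step stays open-ended, as compound 2 stands only at a limit of the assay: the limit of > 1600000 nM in this assay, at which 1 of the 3 values shown sits.

Going by these compounds, whether a saturated pentyl chain would sit nearer compound 1 or compound 3 remains open. So does the question of whether a phenyl without its fluorine would match compound 2.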